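The source may report more compounds than this note shows. Statements on the series, on what has been measured and on what is new or still open speak of the compounds shown alone.

Within the data shown here, the three compounds measured so far share one core and differ only in the aryl group on an amide-type nitrogen. Compound 1 `O=C(Nc1ccc(Nc2ncnc3c2OCCN3)cc1)Nc1ccc(C(F)(F)F)cc1` carries a 4-(trifluoromethyl)phenyl there, and in an assay on isolated protein for inhibition of proto-oncogene tyrosine-protein kinase receptor Ret variant V804M (Homo sapiens), read by 33P incorporation, with stated times of 15 min and 40 min (on this read-out lower numbers stand for stronger inhibition and higher numbers for weaker inhibition), compound 1 gives 276 nM. Compound 2 `O=C(Nc1ccc(Nc2ncnc3c2OCCN3)cc1)Nc1cc(Cl)cc(Cl)c1` carries a 3,5-dichlorophenyl instead, and in this assay compound 2 gives 1300 nM, which is a 4.7-fold higher number from compound 1 to compound 2 (0.67 log units; beyond the scatter). Compound 3 `O=C(Nc1ccc(Nc2ncnc3c2OCCN3)cc1)Nc1cccc2ccccc12` carries a naphthalen-1-yl. In this assay compound 3 reaches only the limit of > 10000 nM, so no number is known for it. Against the other two this is an at least 36-fold higher number from compound 1 to compound 3 (1.55 log units; beyond the scatter) and an at least 7.6-fold higher number from compound 2 to compound 3 (0.88 log units; beyond the scatter); compound 3 thus stands at the weak end of the set, at the limit of > 10000 nM in this assay, at which 1 of the 3 values shown sits.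

Compound 4 `O=C(Nc1ccc(Nc2ncnc3c2OCCN3)cc1)Nc1cccs1` is the next step: thiophen-2-yl in place of naphthalen-1-yl on an amide-type nitrogen. The two measured steps that end at compound 3 were both beyond the scatter and both worsened the number, so leaving the naphthalen-1-yl for a smaller aryl is expected to move the number in this assay back down, though the limit at compound 3 makes the size of that move uncertain. The thiophen-2-yl is expected to give an at least 4.0-fold lower number from compound 3 to compound 4 (0.60 log units; beyond the scatter). For compound 4 the estimate in this assay is 2500 nM, within a range of 600 nM to 10000 nM.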

Compound 4, half-maximal inhibitory concentration: 8640 nM
For compound 4 the middle estimate is 3.5-fold (0.54 log units) below the measured one, and the stated range covers the measured number.
By their numbers in this assay, from the lowest: compound 1; then compound 2; then compound 4. At a limit, above all of these: compound 3.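

In this assay, the thiophen-2-yl on the amide-type nitrogen does not hold the numbers of the two substituted phenyl groups: the change gives a 6.6-fold higher number from compound 2 to compound 4 (0.82 log units; beyond the scatter) and a 31-fold higher number from compound 1 to compound 4 (1.50 log units; beyond the scatter). Leaving the naphthalen-1-yl for a single, smaller aromatic ring is therefore not enough on its own to bring the number close to those of compound 1 or compound 2, so at this position the size of the aryl group alone does not set the number. The thiophen-2-yl in place of the naphthalen-1-yl gives an at least 1.1-fold lower number from compound 3 to compound 4 (0.06 log units; that floor lies within the scatter). Whether that step is a real gain cannot be read, and the limit of compound 3 is the reason: the limit of > 10000 nM in this assay, at which 1 of the 4 values shown sits.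

On these data alone, it remains open whether a plain phenyl, a 4-chlorophenyl or a pyridin-3-yl on this nitrogen would give a number nearer that of compound 1 or that of compound 4. Also open, as far as these compounds go, is whether a trifluoromethyl group on the thiophen-2-yl would recover the number of compound 1, which would show whether the ring itself or the group it carries accounts for the steps seen here.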